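Amide series: methyl to methoxycarbonyl, expected potency

A few compounds are considered here, and "the series" means these few. Any claim that something is new, unique, unknown or untested is made for them only; others in the source may bear on it.

compound 1 `CN(C)c1ccc(C(=O)Nc2cccc(NC(=O)COc3ccc4c(c3)OCCO4)c2)cc1` — in an assay on isolated protein for inhibition of Rho-associated protein kinase 2 (Homo sapiens), read by scintillation counting, radiometric assay and 33P incorporation, with a stated time of 40 min, in the presence of a further agent that is not named here (a lower number here means a stronger inhibitor, a higher number a weaker inhibitor), compound 1 reaches only a limit, > 10000 nM
compound 2 `Cc1coc2cc(OCC(=O)Nc3cccc(NC(=O)c4ccc(N(C)C)cc4)c3)ccc2c1=O` — in this assay compound 2 gives 2150 nM
compound 3 `Cc1ccc(C(=O)Nc2cccc(NC(=O)COc3ccc4c(=O)ccoc4c3)c2)cc1` — in this assay compound 3 gives 22 nM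

Of the two numerical values, compound 3 carries the lowest number; compound 2 stands far higher, well beyond the scatter, so compound 3 is the stronger inhibitor of the pair by a wide margin. Compound 1 reports no number at all: the limit of > 10000 nM in this assay, at which 1 of the 3 values shown sits. Going by the values given here, none of the three measured compounds differ from one another in a single place, so no measured step exists against which a new change could be calibrated.

Compound 4 `COC(=O)c1ccc(C(=O)Nc2cccc(NC(=O)COc3ccc4c(=O)ccoc4c3)c2)cc1` is the next compound and differs from compound 3 in one place only: methoxycarbonyl in place of methyl on an aromatic carbon. The change sits on the aromatic carbon of a six-membered aromatic ring of carbon only, para to a large group.

Among the compounds with values here, with no measured step of this kind, the size of the change is an expectation only. Compound 4 is expected to remain an active inhibitor but to lose some potency relative to compound 3, with a step of the order a 3.6-fold higher number from compound 3 to compound 4 (0.56 log units; beyond the scatter) expected, a little beyond the scatter. In this assay compound 4 is estimated at 80 nM, with a range of 15 nM to 500 nM.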

Compound 4, half-maximal inhibitory concentration: 29 nM
Estimate against measurement, compound 4: 2.8-fold (0.44 log units) above; low and high end bracket the measured number.
By their numbers in this assay, from the lowest: compounds 3 and 4 (each within the scatter of the next); then compound 2. At a limit, above all of these: compound 1.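

In this assay, going by these compounds alone, this is the first step between measured compounds that differ in one place, and it shows methoxycarbonyl and methyl reading alike on this aromatic carbon, para to a large group: a 1.3-fold higher number from compound 3 to compound 4 (0.12 log units; within the scatter). The exchange replaces 1 heavy atom with 4 and adds 2 hydrogen-bond acceptors, yet the step stays within the scatter, so at this position, in this one pair, the larger group is accepted without a measurable loss of inhibition. Nothing measured here bears on why the two compounds read alike.

As far as these compounds go, whether this tolerance extends to other groups at the same position remains open, for instance a carboxylic acid, an amine, or a longer chain such as ethoxycarbonyl. From the compounds shown here alone, it is also open whether the exchange of methyl for methoxycarbonyl would give a similar step on another core, such as that of compound 1 or compound 2, since a single pair cannot show how far the result carries.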